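Dropping a Cyano Group from Compound 1

The source may report more compounds than this note shows. Statements on the series, on what has been measured and on what is new or still open speak of the compounds shown alone.

Measured compounds:
compound 1 `N#Cc1ccc(NC(=S)N/N=C/c2ccc3ccccc3n2)cc1`: 15600 nM
compound 2 `CN(C)C(=S)N/N=C/c1nc2ccccc2s1`: 250 nM

Compound 1 has the highest number of the two in a functional assay on HT-29 cells (Homo sapiens) for antiproliferative activity, read by sulforhodamine B assay, with a stated time of 72 h (a higher number here means a weaker inhibitor, a lower number a stronger inhibitor), giving 15600 nM. Compound 2 gives 250 nM in this assay, a lower number beyond the scatter; the two share no core, so their gap says nothing about one change alone.

Compound 3 `S=C(N/N=C/c1ccc2ccccc2n1)Nc1ccccc1` differs from compound 1 by hydrogen in place of cyano on an aromatic carbon. For the measured compounds named here, no measured pair isolates this change. The step of a 1.6-fold lower number from compound 1 to compound 3 (0.19 log units; within the scatter) is expected to be small, at most slightly toward a lower number. Compound 3 is therefore estimated at 10000 nM, within 3000 nM to 35000 nM.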

Compound 3, half-maximal inhibitory concentration: 17000 nM
Estimate against measurement, compound 3: 1.7-fold (0.23 log units) below; the range from low to high includes it.
By their numbers in this assay, from the lowest: compound 2; then compounds 1 and 3 (each within the scatter of the next).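

In this assay, for the compounds shown here, the first pair to isolate this change shows a 1.1-fold higher number from compound 1 to compound 3 (0.04 log units; within the scatter). At this aromatic carbon, para to a large group, going from 4-cyanophenyl to phenyl therefore leaves the number within the scatter, so the nitrile makes no measurable difference to antiproliferative activity on this core. No measurement shown here bears on this result. As far as these compounds go, whether an amine, a methoxy group or a carboxylic acid on that carbon would move the number beyond the scatter remains open. So does whether removing the nitrile would have equally little effect on another core.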